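The source may report more compounds than this note shows. Statements on the series, on what has been measured and on what is new or still open speak of the compounds shown alone.

Measured so far:
- Compound 2, `COC(=O)[C@@]1(C)CC[C@@H]2C3=C1CC[C@@H](C)[C@]3(C)Cc1c2[nH]c2ccccc12`, gives 3500 nM in a functional assay on HBL-100 cells (Homo sapiens) for inhibition, read by sulforhodamine B assay, with a stated time of 48 h; on this read-out lower numbers stand for stronger inhibition of growth and higher numbers for weaker inhibition of growth.
- Compound 1, `COC(=O)[C@@]1(C)CCC=C2[C@@H]1CC[C@@H](C)[C@]2(C)Cc1c(C)[nH]c2ccc(C(F)(F)F)cc12`, gives 16000 nM in this assay.

Compound 2 has the lower of the two numbers; the number for compound 1 is higher by a margin beyond the usual scatter. Compound 3, `COC(=O)[C@@]1(C)CC[C@@H]2C3=C1CC[C@@H](C)[C@]3(C)Cc1c2[nH]c2ccc(C)cc12`, differs from compound 2 by methyl in place of hydrogen on an aromatic carbon. Among the compounds with values here, no pair of measured compounds differs by a single change of this kind, so there is no measured step to compare with. Since the change is a single small group, the expected step of a 1.2-fold lower number from compound 2 to compound 3 (0.07 log units; within the scatter) is no larger than the scatter, in either direction. Compound 3 is therefore estimated at 3000 nM, with a range from 1200 nM to 8000 nM.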

Compound 3, concentration for 50% growth inhibition: 11000 nM
Estimate against measurement, compound 3: 3.7-fold (0.56 log units) below; the whole stated range lies below it.
By their numbers in this assay, from the lowest: compound 2; then compounds 3 and 1 (each within the scatter of the next).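

In this assay, methyl in place of hydrogen on this aromatic carbon gives a 3.1-fold higher number from compound 2 to compound 3 (0.50 log units; beyond the scatter) as the only single-place change among these compounds. It shows that this position is not indifferent: even one added carbon here weakens growth inhibition by more than the scatter. No data shown here give a reason for this step. From the compounds shown here alone, whether fluorine, a hydroxyl group or an amine at this position would also raise the number remains open. So does whether a longer chain, such as ethyl, would raise it further.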